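Swapping the Azole Ring of Compound 2

The compounds below may be only part of what the source reports. "The series", "measured", "known", "first", "only" and "open" are said of these compounds alone.

Measured compounds:
Compound 1 `Fc1ccc(-c2[nH]c3cc(Cl)ccc3c2Cn2ccnc2)cc1` gives 32.3 nM in an assay on isolated protein for inhibition of Aromatase (Homo sapiens), read by ELISA, using NADPH, with a stated time of 24 h; on this read-out lower numbers stand for stronger inhibition and higher numbers for weaker inhibition.
Compound 2 `COc1ccc2c(Cn3ccnc3)c(-c3ccc(F)cc3)[nH]c2c1` gives 109 nM in this assay.
Compound 3 `COc1ccc2c(Cn3ccnc3)c(-c3ccc(Cl)cc3)[nH]c2c1` gives 1060 nM in this assay.

Compound 2 holds the second highest of the three numbers. Its nearest neighbour is compound 1, reached by the step of a 3.4-fold higher number from compound 1 to compound 2 (0.53 log units; beyond the scatter); its furthest is compound 3, reached by the step of a 9.7-fold higher number from compound 2 to compound 3 (0.99 log units; beyond the scatter). Both steps lie beyond the usual scatter, so compound 2 sits clearly between the other two.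

Compound 4 `COc1ccc2c(Cn3cncn3)c(-c3ccc(F)cc3)[nH]c2c1` differs from compound 2 in one place: 1H-1,2,4-triazol-1-yl in place of 1H-imidazol-1-yl on a saturated chain carbon bound to an aromatic carbon. Neither measured step touches this part of the molecule. The step from compound 1 to compound 2 and the step from compound 2 to compound 3 both alter a substituent on an aromatic carbon and leave the azole ring unchanged, so they give no direct guide to the size or direction of the present change. With no comparable step on record, the change is expected to produce at most a modest shift, and the direction cannot be inferred from these compounds alone. The step from compound 2 to compound 4 is therefore estimated as a 1.2-fold higher number from compound 2 to compound 4 (0.08 log units; within the scatter). Compound 4 is expected to give 130 nM in this assay, within a range from 35 nM to 500 nM.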

Compound 4, half-maximal inhibitory concentration: 238 nM
Compound 4: middle estimate off by 1.8-fold (0.26 log units), on the low side; low and high end bracket the measured number.
By their numbers in this assay, from the lowest: compound 1; then compound 2; then compound 4; then compound 3.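

In this assay, the azole ring on the saturated chain carbon bound to an aromatic carbon turns out to matter: 1H-1,2,4-triazol-1-yl in place of 1H-imidazol-1-yl gives a 2.2-fold higher number from compound 2 to compound 4 (0.34 log units; beyond the scatter), a modest change but one beyond the usual scatter. Going by these compounds alone, the earlier steps altered only substituents on aromatic carbons, so this is the first sign that the number also responds at this position, even to a swap that keeps the ring size and the heavy-atom count and only exchanges a ring carbon for a nitrogen. Nothing available on this pair explains the shift, so the result records its direction and size but not its origin.

On these data alone, this is a single pair, with the methoxy and the fluoro group held fixed, so it remains open whether the same swap would shift the number similarly with the chloro substituents found in compound 1 or compound 3. Also open, as far as these compounds go, is how the number would respond to a different group at this position, such as a 1H-tetrazol-1-yl ring or an amine, or to a longer chain carrying the azole ring.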